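A few compounds are considered here, and "the series" means these few. Any claim that something is new, unique, unknown or untested is made for them only; others in the source may bear on it.

Two measured compounds open the series. Compound 1 `CCCCCCCCCCCCC#Cc1cn([C@H]2CC[C@@H](CO)O2)c(=O)[nH]c1=O` sits at a limit: in an ADME assay on Vero cells (Homo sapiens) for cytotoxicity against Vero (Chlorocebus sabaeus), read by MTT assay (a lower number here means that less compound is tolerated, a higher number that more compound is tolerated), compound 1 gives > 100 ug/mL, a limit of the assay rather than a number. Compound 2 `CCCCCCCCC#Cc1cn([C@H]2C[C@H](F)[C@@H](CO)O2)c(=O)[nH]c1=O` likewise reaches only a limit, with > 100 ug/mL in this assay. Both values sit at the limit of > 100 ug/mL in this assay, at which 2 of the 2 values shown sit, so compound 2 stands at the same limit as the other compound shown. Compound 3 `CCCCCCCCCCCC#Cc1cn([C@H]2C[C@H](F)[C@@H](CO)O2)c(=O)[nH]c1=O` is not yet measured; it differs from compound 2 by propyl in place of hydrogen on a saturated chain carbon, eight bonds along the chain from a triple-bonded carbon. Among the measured compounds shown here, no step between measured compounds exists here, and no change beyond the scatter is expected; the step is estimated as a number no higher from compound 2 to compound 3 (the limit leaves the size open). Compound 3 is expected to give 100 ug/mL, within 50 ug/mL to 200 ug/mL.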

Compound 3, half-maximal cytotoxic concentration: > 100 ug/mL
Compound 3 gave a limit, no number (the forecaster's own chance of this, stated with the estimate: 80%); the middle value sits exactly at the limit.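

The step from compound 2 to compound 3 cannot be read, as both values are limits, not numbers, in this assay: the limit of > 100 ug/mL in this assay, at which 3 of the 3 values shown sit. The compounds shown leave open what concentration of compound 1, compound 2 or compound 3 would reach the half-maximal cytotoxic effect.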